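Swapping a halogen pattern on a shared core

The source may hold more compounds than are shown below. What is called first, only, known or untested is meant among the compounds shown, and "the series" means these compounds.

Compound 1, `COc1ccc(C(=O)/C=C/c2cc(OC)c(OC)c(OC)c2)c2c1C=CC(C)(C)O2`: in a functional assay on SW-620 cells (Homo sapiens) for antiproliferative activity, read by MTT assay, with a stated time of 24 h (a higher number here means a weaker inhibitor, a lower number a stronger inhibitor), compound 1 gives 9150 nM.
Compound 2, `COc1cc(OC)c(OC)cc1/C=C/C(=O)c1ccc(OC)c2c1OC(C)(C)C=C2`: in this assay compound 2 gives > 10000 nM, which is a limit of the assay rather than a number.
Compound 3, `COc1ccc(C(=O)/C=C/c2cccc(F)c2)c2c1C=CC(C)(C)O2`: in this assay compound 3 gives > 10000 nM, likewise a limit of the assay and not a number.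

Compound 3 therefore stands on no measured number at all; only a limit is known for it, and one of the other two values shown is a limit as well, as the limit of > 10000 nM in this assay, at which 2 of the 3 values shown sit, records. Compound 1 alone has a number, and that number sits close to the limit. For the measured compounds named here, no two of the three measured compounds differ in a single place, so no measured step is available to guide the next move.

Compound 4, `COc1ccc(C(=O)/C=C/c2ccc(Cl)c(Cl)c2)c2c1C=CC(C)(C)O2`, differs from compound 3 in one place: 3,4-dichlorophenyl in place of 3-fluorophenyl on a double-bonded chain carbon bound to a double-bonded chain carbon. With compound 3 at the limit, a real step in this assay could only be seen if compound 4 turned out a stronger inhibitor; a weaker one would return another limit. The expected step is small, a number no higher from compound 3 to compound 4 (the limit leaves the size open), with compound 4 expected to remain a weak inhibitor. Compound 4 is estimated at 10000 nM, within a range from 3000 nM to 30000 nM, and a further limit is the likelier outcome.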

Compound 4, half-maximal inhibitory concentration: 7700 nM
The estimate for compound 4 lay 1.3-fold (0.11 log units) above the measured number; the measured number falls inside the stated range.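

In this assay compound 4 gives 7700 nM as a measured number, so with 3,4-dichlorophenyl on a double-bonded chain carbon bound to a double-bonded chain carbon, the shared core gives a reading inside the measurable range. Compound 3 gives > 10000 nM in this assay, which is a limit of the assay and not a number. Exchanging 3-fluorophenyl for 3,4-dichlorophenyl therefore reads as an at least 1.2-fold lower number from compound 3 to compound 4 (0.11 log units; that floor lies within the scatter) and that figure is only a floor, so the change may be no real gain or may be a larger one, and one end of it rests on a limit shared with another compound: the limit of > 10000 nM in this assay, at which 2 of the 4 values shown sit.

The fluorine leaves and the two chlorines enter in a single change, so the compounds shown cannot separate what the loss of one halogen does from what the arrival of the others does, nor say whether a single chlorine on the phenyl ring would be enough. From the compounds shown here alone, what a phenyl ring carrying an amine or a carboxylic acid would give at this place also remains open.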